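A few compounds are considered here, and "the series" means these few. Any claim that something is new, unique, unknown or untested is made for them only; others in the source may bear on it.

The measured compounds and their results in a functional assay on MCF7 cells (Homo sapiens) for cytotoxicity, read by sulforhodamine B assay, with a stated time of 48 h, tested at 1 uM (on this read-out lower numbers stand for a stronger effect and higher numbers for a weaker effect at the one concentration tested), are:
compound 1, `COc1cc(-c2cc(/C=C/C(=O)c3ccc(N)cc3)[nH]n2)cc(OC)c1OC`, 66%;
compound 2, `COc1ccc(-c2cc(/C=C/C(=O)c3ccc(OC)c(OC)c3)[nH]n2)cc1`, 27%;
compound 3, `COc1cc(-c2cc(/C=C/C(=O)c3ccc(Cl)c(Cl)c3)[nH]n2)cc(OC)c1OC`, 62%.

Compound 1 gives the highest of the three numbers, which on this read-out means the weakest effect at the single concentration tested. Compound 3 lies closest to it: the change from compound 1 to compound 3 is 3,4-dichlorophenyl in place of 4-aminophenyl on a carbonyl carbon, and the step is a number 4 percentage points lower from compound 1 to compound 3 (within the scatter). Within the data shown here, compound 2 lies furthest away; its value stands beyond the scatter below that of compound 1, but compound 2 differs from compound 1 in more than one place, so no single step joins the two.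

Compound 4, `COc1ccc(-c2cc(/C=C/C(=O)c3ccc(N)cc3)[nH]n2)cc1OC`, has not yet been measured. It differs from compound 1 in one place: hydrogen in place of methoxy on an aromatic carbon. Among the measured compounds shown here, none of the measured steps touches a change of this kind; the only single step available, from compound 1 to compound 3, alters a different ring and stays within the scatter. These data therefore give no reason to expect a shift in either direction, and compound 4 is expected to give a number close to that of compound 1, the expected step being a number 6 percentage points lower from compound 1 to compound 4 (within the scatter). The estimate for compound 4 is 60%, with a range from 40% to 80%.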

Compound 4, a percentage reported as activity, at one concentration (the size of the read-out at that concentration, not a potency): 81%
Compound 4: middle estimate off by 21 percentage points, on the low side; measured number above the stated range.
By their numbers in this assay, from the lowest: compound 2; then compounds 3 and 1 (each within the scatter of the next); then compound 4.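

Hydrogen in place of methoxy, on an aromatic carbon ortho to one methoxy group and meta to another, is a change at this position that can be read on its own, and in this assay it gives a number 15 percentage points higher from compound 1 to compound 4 (beyond the scatter). Among these compounds, the group at this position therefore has a modest but readable bearing on the result: with hydrogen there, the number rises and the effect at the one concentration tested is weaker, whereas the only earlier single step, a number 4 percentage points lower from compound 1 to compound 3 (within the scatter), changed the group on the carbonyl carbon and stayed within the scatter. Nothing given here explains why removing this methoxy group weakens the effect.

Going by these compounds, it remains open whether the methoxy group itself matters or whether another group at this position, such as a hydroxyl, an ethoxy or a fluorine, would serve as well or better. On these data alone, it is also open whether the same swap would weaken the effect in a compound carrying 3,4-dichlorophenyl on the carbonyl carbon instead of 4-aminophenyl, and these single-concentration numbers say nothing about potency.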